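The source may report more compounds than this note shows. Statements on the series, on what has been measured and on what is new or still open speak of the compounds shown alone.

Measured compounds:
compound 1, `ClCc1cccc(Cn2cnc3c(Cl)ncnc32)c1`: 3800 nM
compound 2, `ClCc1cccc(Cn2cnc3c(Cl)nc(Cl)nc32)c1`: 3310 nM
compound 3, `ClCc1ccccc1Cn1cnc2ncnc(Cl)c21`: 2080 nM

The three measured compounds were tested in a functional assay on RPMI-8226 cells (Homo sapiens) for cytotoxicity, read by sulforhodamine B assay, with a stated time of 48 h; on this read-out lower numbers stand for stronger inhibition of growth and higher numbers for weaker inhibition of growth. Compound 1 gives 3800 nM in this assay, compound 2 gives 3310 nM, and compound 3 gives 2080 nM. All three numbers lie within the usual scatter of one another, so no order among them can be claimed.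

Compound 2 differs from compound 1 by one change, (chloro in place of hydrogen on an aromatic carbon). The step that this change made is a 1.1-fold lower number from compound 1 to compound 2 (0.06 log units; within the scatter).

Compound 4, `ClCc1ccccc1Cn1cnc2nc(Cl)nc(Cl)c21`, has not yet been measured in this assay. It differs from compound 3 by chloro in place of hydrogen on an aromatic carbon. The place of this change is described in the same words as the place of the change from compound 1 to compound 2, so it is the same change, made on a different core. Compound 3 and compound 1 are built from the same atoms joined differently; the difference between the two cores is not broken down here.

Because the earlier step of a 1.1-fold lower number from compound 1 to compound 2 (0.06 log units; within the scatter) lay within the scatter, the same change is expected to move the number from compound 3 only a little. The expected step from compound 3 to compound 4 is a 1.1-fold lower number from compound 3 to compound 4 (0.04 log units; within the scatter). Compound 4 is estimated to give 1900 nM in this assay, with a likely range from 1000 nM to 3800 nM.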

Compound 4, concentration for 50% growth inhibition: 210 nM
Estimate against measurement, compound 4: 9.0-fold (0.96 log units) above, outside the stated range (below it).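

In this assay, chloro in place of hydrogen on an aromatic carbon, at the place between two ring nitrogen atoms, gives a 9.9-fold lower number from compound 3 to compound 4 (1.00 log units; beyond the scatter), so on the core of compound 3 this change goes with a clear drop in the number. The same change therefore cannot be carried from one core to the other in this series with its size intact, as the two steps set side by side show: the same change on two cores in this assay, a 1.1-fold lower number (0.06 log units; within the scatter) from compound 1 to compound 2 and a 9.9-fold lower number (1.00 log units; beyond the scatter) from compound 3 to compound 4, 8.6-fold (0.94 log units) apart, beyond the scatter of two such steps. This rests on a single pair on each of two cores built from the same atoms joined differently, so it shows that the size of the step depends on the core in these two cases, but it does not show which difference between the cores accounts for the gap or what size the step would take on any further core.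

The compounds shown leave open whether another group at that same place, such as an amine, a methoxy group or a fluoro group, would give a step of like size on the core of compound 3. They also leave open whether the step on that core would hold if the chloromethyl group gave way to a methyl group or a hydroxymethyl group.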